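The source may hold more compounds than are shown below. What is called first, only, known or untested is meant among the compounds shown, and "the series" means these compounds.

In an assay on isolated protein for inhibition of protein deacetylase HDAC6 (Homo sapiens), read by fluorescence (a higher number here means a weaker inhibitor, a lower number a stronger inhibitor), compound 3 `C#CCN(C)CCCOc1cc(NC(=O)CCCCCCC(=O)NO)c(Cl)cc1Cl` gives 60 nM, the lowest of the three numbers shown, although compound 2 `C#CCN(C)CCCOc1cc(NC(=O)CCCCCCCC(=O)NO)ccc1Cl`, giving 80 nM, lies within the scatter of it; compound 1 `C#CCN(C)CCCOc1cc(NC(=O)CCCCCCCCC(=O)NO)ccc1Cl` gives 160 nM, beyond the scatter. Compound 4 `C#CCN(C)CCCOc1cc(NC(=O)CCCCCCC(=O)NO)ccc1Cl` carries hydrogen in place of chloro on an aromatic carbon. Among the compounds with values here, none of the measured steps touches this change: the only single-point step, a 2.0-fold lower number from compound 1 to compound 2 (0.30 log units; within the scatter), concerns chain length, and compounds 2 and 3 differ in two places at once, so their values alone say little about the chloro. Within the data shown here, with no precedent in this set, a change of no more than the scatter is expected for a 1.5-fold higher number from compound 3 to compound 4 (0.18 log units; within the scatter), with the direction open. Compound 4 is therefore estimated at 90 nM, with a range from 40 nM to 200 nM.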

Compound 4, half-maximal inhibitory concentration: 10 nM
The estimate for compound 4 lay 9.0-fold (0.95 log units) above the measured number, outside the stated range (below it).
By their numbers in this assay, from the lowest: compound 4; then compounds 3, 2 and 1 (each within the scatter of the next, the first and the last beyond it).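

In this assay, this aromatic carbon, ortho to a large group, proves sensitive to the change, with hydrogen in place of chloro giving a step beyond the scatter (a 6.0-fold lower number from compound 3 to compound 4 (0.78 log units; beyond the scatter)). Chain length also matters more than the earlier step suggested, as the shorter chain of compound 4 gives an 8.0-fold lower number from compound 2 to compound 4 (0.90 log units; beyond the scatter) and a 16-fold lower number from compound 1 to compound 4 (1.20 log units; beyond the scatter) in the two comparisons with the longer chains. No evidence is available to account for either step. Going by these compounds, it remains open how fluoro or methoxy would behave at this aromatic carbon. On these data alone, whether a still shorter chain would continue the trend also remains open.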